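The source may report more compounds than this note shows. Statements on the series, on what has been measured and on what is new or still open speak of the compounds shown alone.

In a functional assay on MV4-11 cells (Homo sapiens) for antiproliferative activity, read by luminescence and CellTiter-Glo, with a stated time of 72 h (a higher number here means a weaker inhibitor, a lower number a stronger inhibitor), compound 1 `Cc1ccc(Cn2nc(Nc3ccc(C#N)cc3)c3ccc(-c4c(C)noc4C)cc32)cc1` gives 5800 nM and compound 2 `COc1ccc(Cn2nc(Nc3ccc(F)cc3OC)c3cc(-c4c(C)noc4C)ccc32)cc1` stands as "not determined" (no result reported) without a number. Compound 3 `CNc1cc(-c2ccc3cnn(Cc4ccc(F)cc4)c3c2)cn(C)c1=O` gives 2390 nM as the lower of the two numbers, and its gap to compound 1 lies beyond the usual scatter. Compound 4 `CNc1cc(-c2ccc3cnn(Cc4ccc(F)c([N+](=O)[O-])c4)c3c2)cn(C)c1=O` differs from compound 3 by nitro in place of hydrogen on an aromatic carbon in one place: nitro in place of hydrogen on an aromatic carbon, ortho to a fluoro group, so that 4-fluorophenyl becomes 4-fluoro-3-nitrophenyl. Going by the values given here, no measured pair shows such a change, and with compound 3 at 2390 nM as the only base, no step beyond the scatter is expected. The estimated 1.2-fold lower number from compound 3 to compound 4 (0.08 log units; within the scatter) stays within the scatter. Compound 4 is estimated at 2000 nM with 700 nM to 6000 nM as its expected range.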

Compound 4, half-maximal inhibitory concentration: 130 nM
Estimate against measurement, compound 4: 15-fold (1.19 log units) above; the measured number lies below the stated range.
By their numbers in this assay, from the lowest: compound 4; then compound 3; then compound 1.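

The only single-place step shown, an 18-fold lower number from compound 3 to compound 4 (1.26 log units; beyond the scatter) in this assay, reveals that this aromatic carbon, ortho to a fluoro group, is highly sensitive to substitution: nitro there, giving 4-fluoro-3-nitrophenyl, moves the number well beyond the scatter. Compound 1 and compound 3 differ in more than one place and could not show this. Nothing measured here accounts for the size of the step. Going by these compounds, whether the gain is specific to nitro remains open, since an amine or a carboxylic acid on the same carbon would be needed to tell. On these data alone, whether it depends on the fluoro group also remains open.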